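The source may report more compounds than this note shows. Statements on the series, on what has been measured and on what is new or still open speak of the compounds shown alone.

Measured in a functional assay on DU-145 cells (Homo sapiens) for antiproliferative activity, read by MTT assay, with a stated time of 24 h; a higher number here means a weaker inhibitor, a lower number a stronger inhibitor:
compound 1 `COc1ccc(C(=O)/C=C/c2cc(-c3cc(OC)c(OC)c(OC)c3)n3nc(-c4ccccc4)cc3n2)cc1OC`: 29900 nM
compound 2 `COc1cc(-c2cc(/C=C/C(=O)c3ccc(C)c(C)c3)nc3cc(-c4ccccc4)nn23)cc(OC)c1OC`: 15400 nM
compound 3 `COc1cc(-c2cc(C(=O)/C=C/c3ccc(Cl)cc3)nc3cc(-c4ccccc4)nn23)cc(OC)c1OC`: 19500 nM

Compound 3 gives the second highest of the three numbers; its nearest neighbour is compound 2 and its furthest is compound 1, and both gaps lie within the scatter, so the three compounds are not separated. Compound 4 `COc1cc(-c2cc(/C=C/C(=O)c3ccccc3)nc3cc(-c4ccccc4)nn23)cc(OC)c1OC` is the unmeasured member; it differs from compound 3 in one place: 2-benzoylethenyl in place of (2-(4-chlorophenyl)ethenyl)carbonyl on an aromatic carbon. Within the data shown here, the steps that bear on a change of the aryl in this arm are a 1.9-fold lower number from compound 1 to compound 2 (0.29 log units; within the scatter) and a 1.3-fold higher number from compound 2 to compound 3 (0.10 log units; within the scatter), both within the scatter. Hence no step beyond the scatter is expected here, a 1.0-fold higher number from compound 3 to compound 4 (0.01 log units; within the scatter). For compound 4 in this assay the estimate is 20000 nM, with a range from 9000 nM to 45000 nM.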

Compound 4, half-maximal inhibitory concentration: 34300 nM
For compound 4 the middle estimate is 1.7-fold (0.23 log units) below the measured one, and the stated range covers the measured number.
By their numbers in this assay, from the lowest: compounds 2, 3, 1 and 4 (each within the scatter of the next, the first and the last beyond it).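

In this assay, among these compounds, the aryl on the carbonyl carbon gives the first step beyond the scatter, a modest one, with phenyl in place of 3,4-dimethylphenyl (a 2.2-fold higher number from compound 2 to compound 4 (0.35 log units; beyond the scatter)). Phenyl in place of 3,4-dimethoxyphenyl stays within the scatter (a 1.1-fold higher number from compound 1 to compound 4 (0.06 log units; within the scatter)), so the two substituted aryls do not share this step. The exchange of (2-(4-chlorophenyl)ethenyl)carbonyl for 2-benzoylethenyl also stays within it (a 1.8-fold higher number from compound 3 to compound 4 (0.25 log units; within the scatter)).

Open, going by these compounds, is whether an amine or a carboxylic acid on this aryl would move the number further. No measurement at hand accounts for the step from 3,4-dimethylphenyl to phenyl.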